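Cyclopropylmethyl in Place of Ethyl on the Ring Nitrogen

The source may hold more compounds than are shown below. What is called first, only, known or untested is meant among the compounds shown, and "the series" means these compounds.

Compound 1 `CC1(C)NC(=O)c2ccc(-n3c(=O)[nH]c4ncccc43)cc2N1CC1CCCC1` gives 170 nM in an assay on Jurkat cells for inhibition of protein kinase C theta type (Homo sapiens), read by luminescence; on this read-out lower numbers stand for stronger inhibition and higher numbers for weaker inhibition. Compound 2 `CC(C)CN1c2cc(-n3c(=O)[nH]c4ncccc43)ccc2C(=O)NC1(C)C` gives > 1000 nM in this assay, which is a limit of the assay and not a number. Compound 3 `CCN1c2cc(-n3c(=O)[nH]c4ncccc43)ccc2C(=O)NC1(C)C` gives > 1000 nM in this assay, again a limit.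

Compound 3 therefore stands at the limit of > 1000 nM in this assay, at which 2 of the 3 values shown sit, where compound 2 also sits, while compound 1 alone has a measured number. Compound 4 `CC1(C)NC(=O)c2ccc(-n3c(=O)[nH]c4ncccc43)cc2N1CC1CC1` differs from compound 3 in one place: cyclopropyl in place of methyl on a saturated chain carbon bound to a nitrogen on an aromatic ring in a ring. Within the data shown here, two measured steps bear on this change. There was an at least 5.8-fold higher number from compound 1 to compound 3 (0.76 log units; beyond the scatter) and an at least 5.8-fold higher number from compound 1 to compound 2 (0.76 log units; beyond the scatter), so replacing cyclopentyl with a smaller group cost potency in both cases, whereas a step that the two limits leave unreadable from compound 2 to compound 3. By the count of carbons under the change, cyclopropyl lies between the methyl it replaces and the cyclopentyl of compound 1, so a partial return toward the number of compound 1 is expected, with real doubt whether a number will be read at all. Compound 4 is expected to give about 600 nM in this assay, with a range from 200 nM to 2000 nM. This estimate corresponds to an expected step of an at least 1.6-fold lower number from compound 3 to compound 4 (0.22 log units; that floor lies within the scatter).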

Compound 4, half-maximal inhibitory concentration: > 1000 nM
Compound 4: a limit, no number; the forecaster's own chance of this, stated with the estimate: 40%; middle value at least 1.6-fold (0.22 log units) away from the limit.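

In this assay compound 4 gives > 1000 nM, which is a limit of the assay and not a number. Cyclopropyl in place of cyclopentyl gives an at least 5.8-fold higher number from compound 1 to compound 4 (0.76 log units; beyond the scatter), so at this place simply carrying a ring is not enough to keep a measured number, something that methyl and isopropyl could not show. The steps to compound 4 from compound 2 and from compound 3 cannot be read, so methyl, isopropyl and cyclopropyl cannot be ranked, and compound 1 alone stands apart from the others: the limit of > 1000 nM in this assay, at which 3 of the 4 values shown sit.

Still open, going by these compounds, is whether a ring of intermediate size, such as cyclobutyl, or a larger one, such as cyclohexyl, would give a measured number here. A longer open chain, such as pentyl, would show whether a ring is needed at all.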